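This account rests on a few compounds, and the source may have more. Where it says the series, first, only, none or still open, it means among the compounds named here.

Measured compounds:
Compound 1 `CC(/C=N/Nc1nc(N)c2ncn([C@@H]3O[C@H](CO)[C@@H](O)[C@H]3O)c2n1)Cc1ccc(C(C)C)cc1` gives 9500 nM in an assay on CHO-K1 cells for displacement of a labelled ligand from adenosine receptor A1 (Homo sapiens), read by scintillation counting, with a stated time of 60 min; on this read-out lower numbers stand for stronger inhibition and higher numbers for weaker inhibition.
Compound 2 `Nc1nc(N/N=C/c2ccc3ncccc3c2)nc2c1ncn2[C@@H]1O[C@H](CO)[C@@H](O)[C@H]1O` gives 9.8 nM in this assay.
Compound 3 `Nc1nc(N/N=C/c2ccc(-c3ccccn3)cc2)nc2c1ncn2[C@@H]1O[C@H](CO)[C@@H](O)[C@H]1O` gives 7540 nM in this assay.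

Of the three numbers, compound 2 stands lowest. Its nearest neighbour is compound 3, whose number is higher by a margin beyond the scatter, and compound 1 lies further still, also beyond the scatter. Compound 2 is thus the strongest binder among the three.

Compound 4 `COc1ccc(/C=N/Nc2nc(N)c3ncn([C@@H]4O[C@H](CO)[C@@H](O)[C@H]4O)c3n2)cn1` has not yet been measured in this assay. It differs from compound 2 in one place: 6-methoxypyridin-3-yl in place of quinolin-6-yl on a carbon with a double bond to nitrogen. The two six-membered aromatic rings of compound 2 give way to a single six-membered aromatic ring with one hetero atom bearing a methoxy group. Among the measured compounds shown here, with no measured pair of this kind to lean on, the account can only note that compound 2 alone, of the three, reaches a low number, and that the other two aryl and alkyl variants sit far above it. A step in the direction of a higher number, of moderate size, is expected for compound 4, as a 41-fold higher number from compound 2 to compound 4 (1.61 log units; beyond the scatter). Compound 4 is therefore estimated at 400 nM, with a range from 40 nM to 4000 nM.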

Compound 4, inhibition constant: 2.6 nM
The estimate for compound 4 lay 150-fold (2.19 log units) above the measured number, and the stated range ends above it.
By their numbers in this assay, from the lowest: compound 4; then compound 2; then compounds 3 and 1 (each within the scatter of the next).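

In this assay, the exchange of quinolin-6-yl for 6-methoxypyridin-3-yl on the carbon with a double bond to nitrogen gives a 3.8-fold lower number from compound 2 to compound 4 (0.58 log units; beyond the scatter). Among the compounds shown here, until this result, quinolin-6-yl was the only group at this place with a low number, and compound 4 shows that a low number does not depend on the two aromatic rings of compound 2: a single six-membered aromatic ring with one hetero atom, bearing a methoxy group, also reaches one. Nothing at hand explains the step.

The compounds shown leave open how much of the step belongs to the methoxy group and how much to the ring that carries it, as a plain pyridin-3-yl would show. As far as these compounds go, it also remains open whether an ethoxy group or an amine in place of the methoxy group would keep the number this low.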